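The source may hold more compounds than are shown below. What is called first, only, known or untested is meant among the compounds shown, and "the series" means these compounds.

- compound 1 `CC(=O)OC/C1=C/C[C@](C)(CCC=C(C)C)/C=C/[C@@H](OC(=O)C=C(C)C)[C@](C)(O)/C=C/C1=O` with 2950 nM 
- compound 2 `CC(C)=CCC[C@]1(C)/C=C/[C@@H](OC(=O)C=C(C)C)[C@](C)(O)/C=C/C(=O)/C(CCl)=C\C1` with 150 nM 

In a functional assay on A549 cells (Homo sapiens) for antiproliferative activity, read by MTT assay, with a stated time of 48 h (a lower number here means a stronger inhibitor, a higher number a weaker inhibitor), compound 2 has the lower number of the pair, at 150 nM, and so is the stronger inhibitor. Compound 3 `CC(C)=CCC[C@]1(C)/C=C/[C@@H](OC(=O)C=C(C)C)[C@](C)(O)/C=C/C(=O)/C(CN(C)C)=C\C1` differs from it in one place (dimethylamino in place of chloro on a saturated chain carbon bound to a double-bonded ring carbon), with dimethylamino in place of chloro on a saturated chain carbon bound to a double-bonded ring carbon. Dimethylamino has not been measured here. The one relevant result is the large step of a 20-fold lower number from compound 1 to compound 2 (1.29 log units; beyond the scatter), seen when chloro replaced acetoxy at this same place. Losing chloro is therefore expected to give back part of that gain. A higher number is expected in this assay, with an estimated step of a 4.0-fold higher number from compound 2 to compound 3 (0.60 log units; beyond the scatter) overall. Compound 3 is estimated at 600 nM, with an expected range from 150 nM to 2500 nM as its likely span.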

Compound 3, half-maximal inhibitory concentration: 590 nM
Compound 3: middle estimate off by 1.0-fold (0.01 log units), on the high side, and the stated range covers the measured number.
By their numbers in this assay, from the lowest: compound 2; then compound 3; then compound 1.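

Dimethylamino keeps part of the gain over acetoxy at this place: this assay shows a 5.0-fold lower number from compound 1 to compound 3 (0.70 log units; beyond the scatter) for this change. It does not match chloro, however, with a 3.9-fold higher number from compound 2 to compound 3 (0.59 log units; beyond the scatter) when dimethylamino replaces chloro, so the three groups now give a clear order at one position. No measurement here explains that order.

Open questions are whether bromo would stand closer to chloro and whether a ring amine such as morpholine would stand closer to dimethylamino. A free hydroxyl at this place also remains to be placed in the order.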